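The source may hold more compounds than are shown below. What is called first, only, known or untested is meant among the compounds shown, and "the series" means these compounds.

Of the compounds shown here, two have so far been measured in an ADME assay on membranes from liver for displacement of a labelled ligand from Sigma intracellular receptor 2 (Rattus norvegicus), read by scintillation counting, with a stated time of 120 min; on this read-out higher numbers stand for weaker inhibition and lower numbers for stronger inhibition. Compound 1 `O=C(c1ccccc1)N1CCC(N2CCc3ccccc3C(O)C2)CC1` gives 1400 nM. Compound 2 `O=[N+]([O-])c1ccc2c(c1)C(O)CN(CCCCCc1ccccc1)CC2` gives 116 nM, the lowest of the two numbers; the gap to compound 1 lies beyond the scatter, and compound 1 shows the higher number of the pair. Compound 3 `O=[N+]([O-])c1ccc2c(c1)C(O)CN(CCCCOc1ccccc1)CC2` has not yet been measured. It differs from compound 2 in a single place: phenoxy in place of benzyl on a saturated chain carbon, four bonds along the chain from an amine nitrogen in a ring. Within the data shown here, no step between two measured compounds covers this change, so only the two structures and the value of compound 2 can guide an expectation. The chain keeps its length and its aromatic ring, and the count under the difference shows one oxygen entering where a carbon leaves. The step is expected to be small, if anything toward a somewhat higher number, and it may well fall within the scatter; the estimated step is a 1.7-fold higher number from compound 2 to compound 3 (0.24 log units; within the scatter). Compound 3 is therefore expected to give 200 nM in this assay, with a range from 60 nM to 700 nM.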

Compound 3, inhibition constant: 1000 nM
The estimate for compound 3 lay 5.0-fold (0.70 log units) below the measured number; the measured number lies above the stated range.
By their numbers in this assay, from the lowest: compound 2; then compounds 3 and 1 (each within the scatter of the next).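

In this assay, among these compounds, the change to phenoxy in place of benzyl on a saturated chain carbon, four bonds along the chain from an amine nitrogen in a ring, brings an 8.6-fold higher number from compound 2 to compound 3 (0.94 log units; beyond the scatter) and gives the first step that can be read at this place. It shows that this part of the chain is not indifferent to the exchange: the number moves beyond the scatter, although the heavy-atom count and the aromatic ring stay the same and the count differs by one oxygen for one carbon and one hydrogen-bond acceptor. No measurement at hand accounts for the size of this step.

From the compounds shown here alone, whether a sulfur atom in the place of this oxygen, or a longer chain carrying the phenoxy group, would bring the number back toward that of compound 2 remains open. Also open, going by these compounds, is whether the same exchange gives a step of similar size on a core without the nitro group, since this single pair is all that speaks for the change.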